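From acetamide to methyl carbamate on the sulfonyl chain

A few compounds are considered here, and "the series" means these few. Any claim that something is new, unique, unknown or untested is made for them only; others in the source may bear on it.

Three compounds share one core and differ only in the group on the carbonyl carbon of the chain that ends in the sulfonyl group. Compound 1 `CC(C)(C)OC(=O)NCCS(=O)(=O)NC(=O)c1ccc(Nc2nc(NC3(c4ccc(Cl)cc4)CC3)nc(OCC(F)(F)F)n2)cc1` carries a tert-butoxy there, compound 2 `CC(C)OC(=O)NCCS(=O)(=O)NC(=O)c1ccc(Nc2nc(NC3(c4ccc(Cl)cc4)CC3)nc(OCC(F)(F)F)n2)cc1` an isopropoxy, and compound 3 `CC(=O)NCCS(=O)(=O)NC(=O)c1ccc(Nc2nc(NC3(c4ccc(Cl)cc4)CC3)nc(OCC(F)(F)F)n2)cc1` a methyl. In an ADME assay on microsomes from liver (Rattus norvegicus) for metabolic stability, with a stated time of 10 min (a lower number here means that less of the compound is left, a higher number that more of the compound is left), compound 1 gives 93%, compound 2 gives 73%, and compound 3 gives 100%. Compound 3 thus shows the highest of the three numbers; its gap to compound 1 lies within the scatter, whereas its gap to compound 2 lies beyond it. Compound 4 `COC(=O)NCCS(=O)(=O)NC(=O)c1ccc(Nc2nc(NC3(c4ccc(Cl)cc4)CC3)nc(OCC(F)(F)F)n2)cc1` takes the next step: methoxy in place of methyl on a carbonyl carbon. For the measured compounds named here, two measured steps bear on this, since both end at compound 3 and both replace an oxygen-linked group by methyl: a number 7 percentage points higher from compound 1 to compound 3 (within the scatter) and a number 27 percentage points higher from compound 2 to compound 3 (beyond the scatter). The move to compound 4 runs the other way, and among the two carbamates a number 20 percentage points lower from compound 1 to compound 2 (beyond the scatter) shows that the smaller isopropoxy gave the lower number. For compound 4 the expected step is a number 15 percentage points lower from compound 3 to compound 4 (beyond the scatter), a modest fall that may still lie within the scatter. The estimated value for compound 4 is 85%, with a range from 65% to 100%.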

Compound 4, percent of the compound remaining: 100%
Beside the measured number, compound 4's estimate is 15 percentage points below it; low and high end bracket the measured number.
By their numbers in this assay, from the lowest: compound 2; then compounds 1, 3 and 4 (each within the scatter of the next).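

In this assay, methoxy in place of methyl on a carbonyl carbon whose other neighbour is the amide-type nitrogen reads no change at the digits printed from compound 3 to compound 4 (within the scatter) and so shows that, at this position, the added oxygen alone leaves the read-out unmoved, which the two larger carbamates could not show. Among the carbamates, methyl on the oxygen reads alike with tert-butyl (a number 7 percentage points higher from compound 1 to compound 4 (within the scatter)) but apart from isopropyl (a number 27 percentage points higher from compound 2 to compound 4 (beyond the scatter)), so the lower number belongs to compound 2 alone and does not run in step from methyl through isopropyl to tert-butyl. Nothing at hand explains why isopropyl stands apart from the other two groups on the oxygen.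

Going by these compounds, it remains open whether ethoxy on this carbonyl carbon would read with methoxy or with isopropoxy, and whether a dimethylamino group there or a longer chain leading to the sulfonyl group would keep the number where compound 3 and compound 4 have it. On these data alone, it also remains open whether the gap around compound 2 would persist, widen or close at a longer incubation time or in liver microsomes from another species.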